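Furan-2-yl sulfonamide replaces a cyanophenyl group on the pyrrole core

This account rests on a few compounds, and the source may have more. Where it says the series, first, only, none or still open, it means among the compounds named here.

Measured so far:
Compound 1, `CNCc1cc(-c2ccccc2F)n(S(=O)(=O)c2ccc(C)cc2)c1`: 91%
Compound 2, `CNCc1cc(-c2cccnc2F)n(S(=O)(=O)c2cccc(C#N)c2)c1`: 99%

In a functional assay on the whole organism (strain Jcl:SD) for inhibition, with Rattus norvegicus as the target, with stated times of 3 min and 3 h, at a dose of 1 mg/kg by the intravenous route (a lower number here means less inhibition, a higher number more inhibition at the dose given (going by the name of the read-out)), compound 2 gives 99%. Compound 1 gives 91% in this assay, and the two numbers sit within the scatter of each other, so neither compound is set apart from the other. Compound 3, `CNCc1cc(-c2cccnc2F)n(S(=O)(=O)c2ccco2)c1`, has not been measured. It differs from compound 2 by furan-2-yl in place of 3-cyanophenyl on a sulfonyl sulfur. Going by the values given here, no measured pair shows this exchange, so its effect is unknown from the data. The step of a number 9 percentage points lower from compound 2 to compound 3 (within the scatter) is expected to be small and downward, within the scatter, since compound 2 already sits near the top of the read-out with 99%. For compound 3 the estimate in this assay is 90%, with a range from 70% to 99%.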

Compound 3, a percentage reported as inhibition, in the whole organism at one dose (the size of the read-out at that dose, not a potency): 74%
Compound 3: middle estimate off by 16 percentage points, on the high side; the range from low to high includes it.
By their numbers in this assay, from the lowest: compound 3; then compounds 1 and 2 (each within the scatter of the next).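

Furan-2-yl in place of 3-cyanophenyl on a sulfonyl sulfur gives a number 25 percentage points lower from compound 2 to compound 3 (beyond the scatter) in this assay and is the first exchange here that can be read on its own. It shows that the group on this sulfur matters for the read-out at this dose, which compound 1 could not show, as it differs from compound 2 in more than one place. Nothing at hand accounts for the drop.

The compounds shown do not separate the loss of the nitrile from the change of ring. Neither plain phenyl nor thiophen-2-yl on the sulfonyl sulfur appears among them, and either would help to tell those two apart.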